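The compounds below may be only part of what the source reports. "The series", "measured", "known", "first", "only" and "open" are said of these compounds alone.

Within the data shown here, in a functional assay on SF-295 cells (Homo sapiens) for inhibition, read by sulforhodamine B assay, with a stated time of 48 h (a higher number here means a weaker inhibitor of growth, a lower number a stronger inhibitor of growth), compound 2 `Cc1cc(O)ccc1C1=NN(c2ccc(S(C)(=O)=O)cc2)C(=O)CC1` gives 2870 nM, the higher of the only two numbers so far, while compound 1 `Cc1ccc(C2=NN(c3ccc(S(C)(=O)=O)cc3)C(=O)CC2)cc1` gives 400 nM. Compound 2 is therefore the weaker growth inhibitor of the pair.

The next compound is compound 3 `CCc1ccc(C2=NN(c3ccc(S(C)(=O)=O)cc3)C(=O)CC2)cc1`, with 4-ethylphenyl in place of 4-hydroxy-2-methylphenyl on a carbon with a double bond to nitrogen. Among the measured compounds shown here, the hydrogen-bond donor and acceptor counted in the leaving group have no counterpart in the entering one.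

For the measured compounds named here, only one measured step bears on this change. That step, a 7.2-fold higher number from compound 1 to compound 2 (0.86 log units; beyond the scatter), is modest but beyond the scatter, and it came when 4-hydroxy-2-methylphenyl replaced 4-methylphenyl. Compound 3 loses that same group, so a step of similar size in the opposite direction seems likely, towards a lower number. Going by the values given here, no compound with 4-ethylphenyl has been measured, so this rests on a single comparison and the range must stay wide.

The expected change is a 5.7-fold lower number from compound 2 to compound 3 (0.76 log units; beyond the scatter). For compound 3, the estimated value is 500 nM, with an expected range from 200 nM to 1300 nM.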

Compound 3, concentration for 50% growth inhibition: 930 nM
Compound 3: middle estimate off by 1.9-fold (0.27 log units), on the low side, within the range that was stated.
By their numbers in this assay, from the lowest: compound 1; then compound 3; then compound 2.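

In this assay, the change to 4-ethylphenyl gives a 3.1-fold lower number from compound 2 to compound 3 (0.49 log units; beyond the scatter), so at this place, on a carbon with a double bond to nitrogen, a group with no hydrogen-bond donor or acceptor wins back part of the ground lost with 4-hydroxy-2-methylphenyl. Even a very small edit to the group registers: methyl in place of hydrogen on the saturated chain carbon, which turns 4-methylphenyl into 4-ethylphenyl, gives a 2.3-fold higher number from compound 1 to compound 3 (0.37 log units; beyond the scatter), so compound 1 keeps the lowest number of the three. Nothing available explains why the three groups fall in this order.

On these data alone, whether a longer chain such as propyl, or a branched one such as isopropyl, would continue the rise seen on going from 4-methylphenyl to 4-ethylphenyl remains open, as does the result for a plain phenyl or a 4-chlorophenyl group at this place. The hydroxyl and the extra methyl also change together in 4-hydroxy-2-methylphenyl, and a 4-hydroxyphenyl group would be needed to show what the hydroxyl does on its own.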